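Propoxy in place of ethoxy on a saturated amine core

A few compounds are considered here, and "the series" means these few. Any claim that something is new, unique, unknown or untested is made for them only; others in the source may bear on it.

Measured so far:
compound 1, `CCCOc1ccc(C2CNC(=O)CS2)cc1`, 1490 nM
compound 2, `CCOc1ccc(C2CNCCS2)cc1`, 2170 nM

Both compounds were tested in an assay on brain for inhibition of Amine oxidase [flavin-containing] B (Rattus norvegicus); on this read-out lower numbers stand for stronger inhibition and higher numbers for weaker inhibition. Compound 1 gives 1490 nM and compound 2 gives 2170 nM, and these two numbers lie within the usual scatter of each other, so neither compound can be called the stronger inhibitor on this evidence. Among the compounds with values here, the two also differ in more than one place, so no single step between them can be read.

Compound 3, `CCCOc1ccc(C2CNCCS2)cc1`, has not yet been tested. It differs from compound 2 by methyl in place of hydrogen on a saturated chain carbon, two bonds along the chain from an oxygen on an aromatic ring. Compound 1 carries the same propoxy chain on a different core, and the numbers for compound 1 and compound 2 give no sign of a large effect. The expected step in this assay is therefore small, with the number for compound 3 estimated to come out slightly lower than for compound 2, as a 1.4-fold lower number from compound 2 to compound 3 (0.13 log units; within the scatter), but not beyond the scatter with any confidence. Compound 3 is expected to give about 1600 nM, with a range from 500 nM to 5000 nM.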

Compound 3, inhibition constant: 980 nM
Compound 3: middle estimate off by 1.6-fold (0.21 log units), on the high side; the measured number falls inside the stated range.
By their numbers in this assay, from the lowest: compounds 3, 1 and 2 (each within the scatter of the next, the first and the last beyond it).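

Within the data shown here, the change from ethoxy to propoxy gives a 2.2-fold lower number from compound 2 to compound 3 (0.35 log units; beyond the scatter) in this assay and is the first single change that can be read here, since compound 1 and compound 2 differ in more than one place. It shows that methyl in place of hydrogen on a saturated chain carbon, two bonds along the chain from an oxygen on an aromatic ring, does shift the number on this core, though only by a modest step. Nothing in the data explains why the longer chain goes with the lower number.

From the compounds shown here alone, one step gives two points on a chain, not a trend, so it remains open whether a butoxy or pentyloxy chain would lower the number further, leave it about the same or raise it. Going by these compounds, it is also open whether a branched isopropoxy group or a benzyloxy group, with its added aromatic ring, would be tolerated at this oxygen, and whether the same change would give a similar step on the core of compound 1.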